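Swapping the aryl on the amine nitrogen of compound 1

The source may report more compounds than this note shows. Statements on the series, on what has been measured and on what is new or still open speak of the compounds shown alone.

Compound 1 `Fc1cc(NCn2nc(-c3ccc4c(c3)OCCO4)oc2=S)cc(F)c1F` gives 2920 nM in a functional assay, with a stated time of 6 min (on this read-out higher numbers stand for weaker inhibition and lower numbers for stronger inhibition), the lowest of the three numbers seen. Compound 3 `S=c1oc(-c2ccc3c(c2)OCCO3)nn1CNc1ccc(Cl)cc1Cl` gives 8710 nM and compound 2 `FC(F)(F)c1ccccc1NCn1nc(-c2ccc3c(c2)OCCO3)oc1=S` gives 9220 nM. Within the data shown here, the one step that bears on the new compound, a 3.0-fold higher number from compound 1 to compound 3 (0.47 log units; beyond the scatter), changes only the aryl on the amine nitrogen, as does the move to compound 4 `Cc1ccccc1NCn1nc(-c2ccc3c(c2)OCCO3)oc1=S`: 2-methylphenyl in place of 3,4,5-trifluorophenyl on an amine nitrogen. Both other aryls in the set left compound 1 with the lowest number, so a higher number is expected for compound 4, of a modest size, a 2.1-fold higher number from compound 1 to compound 4 (0.31 log units; beyond the scatter). Compound 4 is therefore estimated at 6000 nM, within 2500 nM to 15000 nM.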

Compound 4, half-maximal inhibitory concentration: 3450 nM
Beside the measured number, compound 4's estimate is 1.7-fold (0.24 log units) above it, within the range that was stated.
By their numbers in this assay, from the lowest: compounds 1 and 4 (each within the scatter of the next); then compounds 3 and 2 (each within the scatter of the next).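

In this assay, among these compounds, the 2-methylphenyl on the amine nitrogen is the first change of aryl that stays within the scatter of the 3,4,5-trifluorophenyl (a 1.2-fold higher number from compound 1 to compound 4 (0.07 log units; within the scatter)), so not every swap here costs. It still parts from the other two aryls (a 2.5-fold lower number from compound 3 to compound 4 (0.40 log units; beyond the scatter); a 2.7-fold lower number from compound 2 to compound 4 (0.43 log units; beyond the scatter)), the latter step being only methyl in place of trifluoromethyl on an aromatic carbon. Nothing available explains these differences. On these data alone, whether a 2-methoxyphenyl or a pyridyl on the amine nitrogen would group with compound 1 and compound 4 or with compound 2 and compound 3 stays open.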